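The compounds below may be only part of what the source reports. "The series", "measured", "known", "first", "only" and "open" are said of these compounds alone.

Working notes on the series in an assay on microsomes from brain (strain Sprague-Dawley) for inhibition of Fatty-acid amide hydrolase 1 (Rattus norvegicus), read by HPLC, with stated times of 10 min and 45 min; a higher number here means a weaker inhibitor, a lower number a stronger inhibitor.

Going by the values given here, compound 2 `Cc1ccc(Oc2ccc(-c3nnn(C(=O)N(C)C)n3)cc2)cc1` gives 24 nM in this assay, which puts it second highest of the three numbers so far. Its nearest neighbour is compound 3 `CN(C)C(=O)n1nnc(-c2ccc(Oc3ccc(Cl)c(Cl)c3)cc2)n1`, which gives 11 nM; the furthest is compound 1 `O=C1C=CC(=O)N1Cc1ccc(Oc2ccccc2)cc1`, which gives 4900 nM. Compound 1 differs from compound 2 in more than one place, so only its value is noted.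

Compound 4 `CN(C)C(=O)n1nnc(-c2ccc(-n3cccn3)cc2)n1` is not yet measured. Relative to compound 2 the change is 1H-pyrazol-1-yl in place of 4-methylphenoxy on an aromatic carbon. Among the compounds with values here, the one measured step that bears on this region is a 2.2-fold lower number from compound 2 to compound 3 (0.34 log units; beyond the scatter), where a different six-membered aryl replaces the 4-methylphenyl on the oxygen and the number moves only modestly. Within the data shown here, no measured step removes the oxygen-linked aryl altogether or puts a five-membered ring in its place, so the change from compound 2 to compound 4 goes further than anything measured.

Compound 4 is therefore expected to give a higher number than compound 2, the step of a 6.3-fold higher number from compound 2 to compound 4 (0.80 log units; beyond the scatter) being the estimate. Compound 4 is estimated at 150 nM, with a range from 40 nM to 600 nM.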

Compound 4, half-maximal inhibitory concentration: 8 nM
For compound 4 the middle estimate is 19-fold (1.27 log units) above the measured one, outside the stated range (below it).
By their numbers in this assay, from the lowest: compounds 4 and 3 (each within the scatter of the next); then compound 2; then compound 1.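

In this assay the 4-methylphenoxy group on this aromatic carbon proves dispensable: 1H-pyrazol-1-yl in its place gives a 3.0-fold lower number from compound 2 to compound 4 (0.48 log units; beyond the scatter), so the oxygen-linked six-membered aryl can give way to a five-membered aromatic ring with 2 hetero atoms without the number rising. The change at this position therefore tolerates far more than the swap of one aryl for another on the oxygen had shown, and compound 3 and compound 4 stand within the scatter of each other. No data in hand bear on why the number falls with this change.

Open, from the compounds shown here alone, is whether the ring nitrogens of the 1H-pyrazol-1-yl matter, which a plain phenyl or a 1H-imidazol-1-yl at this place would address. Also open, going by these compounds, is how an amine such as morpholine would fare on the same aromatic carbon.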